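The source may report more compounds than this note shows. Statements on the series, on what has been measured and on what is new or still open speak of the compounds shown alone.

Compound 3 `O=C(c1ccc(F)cc1)N1CC(c2nc(-c3cccc(Cl)c3)no2)C1` stands at the edge of what can be measured: in an assay on HEK293 cells for positive allosteric modulation of metabotropic glutamate receptor 5 (Homo sapiens), read by FLIPR (a lower number here means that less compound is needed, a higher number that more compound is needed for the effect), compound 3 gives > 10000 nM, which is a limit of the assay and not a number. Compound 2 `O=C(C1CCCO1)N1CC(c2nc(-c3cccc(Cl)c3)no2)C1` sits at the same edge, giving > 10000 nM in this assay. Going by the values given here, two of the three values known so far thus share (the limit of > 10000 nM in this assay, at which 2 of the 3 values shown sit). Only compound 1 `O=C(N1CCCCC1)N1CC(c2nc(-c3cccc(Cl)c3)no2)C1` gives a real number, 370 nM in this assay. Compound 4 `CC1CCN(C(=O)N2CC(c3nc(-c4cccc(Cl)c4)no3)C2)C1` has not yet been measured; it differs from compound 3 in one place: 3-methylpyrrolidin-1-yl in place of 4-fluorophenyl on a carbonyl carbon. The measured steps that bear on this change both start from compound 1. Swapping its piperidin-1-yl group for 4-fluorophenyl gave an at least 27-fold higher number from compound 1 to compound 3 (1.43 log units; beyond the scatter), and swapping it for oxolan-2-yl gave an at least 27-fold higher number from compound 1 to compound 2 (1.43 log units; beyond the scatter). The data also show a step that the two limits leave unreadable from compound 2 to compound 3. The change to compound 4 runs the first of these steps backwards, restoring a nitrogen-linked saturated ring on the carbonyl carbon, now a 3-methylpyrrolidin-1-yl group rather than piperidin-1-yl. Given the value of compound 1, compound 4 is expected to show an at least 16-fold lower number from compound 3 to compound 4 (1.22 log units; beyond the scatter). The estimate for compound 4 in this assay is 600 nM, within a range from 200 nM to 3000 nM.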

Compound 4, half-maximal effective concentration: > 10000 nM
Compound 4 ended at the assay's limit (the forecaster's own chance of this, stated with the estimate: 15%); middle value at least 16-fold (1.22 log units) away from the limit.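

Until now, both groups that had replaced piperidin-1-yl on this carbonyl carbon were attached through carbon, so a ring nitrogen at that point might have seemed enough to keep the effect. Compound 4 has such a nitrogen, yet in this assay the change to 3-methylpyrrolidin-1-yl gives an at least 27-fold higher number from compound 1 to compound 4 (1.43 log units; beyond the scatter), so a nitrogen-linked saturated ring alone is not sufficient. The steps among compound 2, compound 3 and compound 4 cannot be read, which leaves these three groups unranked, and piperidin-1-yl remains the only group shown here with a real number, while the others share one limit: the limit of > 10000 nM in this assay, at which 3 of the 4 values shown sit.

Compound 4 differs from compound 1 in both ring size and the added methyl group, and the compounds shown do not separate these two changes. An unsubstituted pyrrolidin-1-yl group or a 3-methylpiperidin-1-yl group on the same carbonyl carbon would be needed to tell whether the smaller ring, the methyl group or both go with the result.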